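A few compounds are considered here, and "the series" means these few. Any claim that something is new, unique, unknown or untested is made for them only; others in the source may bear on it.

The study concerns a set of amides sharing one core and tested in an assay on CHO cells for displacement of a labelled ligand from transient receptor potential cation channel subfamily V member 1 (Rattus norvegicus); a higher number here means a weaker inhibitor, a lower number a stronger inhibitor. Compound 1 `CC(C)(C)c1ccc(CNC(=O)C(C)(C)c2ccc(NS(C)(=O)=O)c(F)c2)cc1` gives 1070 nM in this assay. Compound 2 `COc1cc(C2(C(=O)NCc3ccc(C(C)(C)C)cc3)CC2)ccc1NS(C)(=O)=O` gives 750 nM. Compound 3 `CC(C(=O)NCc1ccc(C(F)(F)F)cc1)c1ccc(NS(C)(=O)=O)c(F)c1` gives 660 nM; the numbers of compound 2 and compound 1 both lie within the usual scatter of this value, so the three compounds cannot be set apart from one another on the data shown.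

Compound 4 `CC(C(=O)NCc1ccc(C2C=CCC2)cc1)c1ccc(NS(C)(=O)=O)c(F)c1` has not yet been measured in this assay. It differs from compound 3 in one place: cyclopent-2-en-1-yl in place of trifluoromethyl on an aromatic carbon, the group sitting para to a large group. Going by the values given here, no measured pair shows this change, so the size of the step can only be expected, not read off. The expected step is a 1.3-fold lower number from compound 3 to compound 4 (0.12 log units; within the scatter), modest and within the scatter, with no firm direction. This expectation rests on compound 3 at 660 nM and compound 1 at 1070 nM, which carry different groups at this place yet give values within the scatter of each other. Compound 4 is therefore estimated at 500 nM, with a range from 150 nM to 1700 nM.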

Compound 4, inhibition constant: 162 nM
The estimate for compound 4 lay 3.1-fold (0.49 log units) above the measured number, within the range that was stated.
By their numbers in this assay, from the lowest: compound 4; then compounds 3, 2 and 1 (each within the scatter of the next).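

In this assay, cyclopent-2-en-1-yl in place of trifluoromethyl on the aromatic carbon gives a 4.1-fold lower number from compound 3 to compound 4 (0.61 log units; beyond the scatter), so a change at this position can move the number by more than the scatter, which compound 1, compound 2 and compound 3 could not show. The entering group brings a five-membered non-aromatic ring of carbon only with one double bond, while the counts of hydrogen-bond donors and acceptors and the net charge stay the same. Nothing in the data shown accounts for the size of this step.

On these data alone, with a single pair, it remains open whether the ring or its double bond goes with the lower number, which a saturated cyclopentyl group at this place could test. Also open, as far as these compounds go, are how an amine or a carboxylic acid would read here, and whether the step carries over to the core of compound 1.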